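Swapping a hydroxyl chain for an imidazole-bearing chain

The compounds below may be only part of what the source reports. "The series", "measured", "known", "first", "only" and "open" are said of these compounds alone.

For the measured compounds named here, compound 2 `CC(O)CSc1nc(NCc2ccc(-c3ccccn3)cc2)c2[nH]nc(C(C)C)c2n1` gives 62 nM in a functional assay on HT cells (Homo sapiens) for antiproliferative activity, read by fluorescence, with a stated time of 72 h (on this read-out lower numbers stand for stronger inhibition of growth and higher numbers for weaker inhibition of growth), the lower of the two numbers measured so far; compound 1 `CC(C)c1n[nH]c2c(NCc3ccc(-c4ccccn4)cc3)nc(SCC(O)CN3CCNCC3)nc12` gives 332 nM. Going by the values given here, the one comparison available, a 5.4-fold lower number from compound 1 to compound 2 (0.73 log units; beyond the scatter), concerns a different place on the chain. Compound 3 `CC(C)c1n[nH]c2c(NCc3ccc(-c4ccccn4)cc3)nc(SCCn3ccnc3)nc12` differs from compound 2 by (1H-imidazol-1-yl)methyl in place of 1-hydroxyethyl on a saturated chain carbon bound to a sulfur. Among the compounds with values here, no measured step speaks directly to this change, so the expectation rests on the loose parallel that attaching a nitrogen ring to this chain gave compound 1 a higher number. For compound 3 a modest rise, a 1.9-fold higher number from compound 2 to compound 3 (0.29 log units; within the scatter), is expected, giving an estimated 120 nM with a range of 40 nM to 400 nM.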

Compound 3, concentration for 50% growth inhibition: 155 nM
Compound 3: middle estimate off by 1.3-fold (0.11 log units), on the low side, within the range that was stated.
By their numbers in this assay, from the lowest: compound 2; then compound 3; then compound 1.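

In this assay, a chain ending in a nitrogen ring without a hydroxyl can still give a low number: 2-(1H-imidazol-1-yl)ethyl in place of 2-hydroxypropyl gives a 2.5-fold higher number from compound 2 to compound 3 (0.40 log units; beyond the scatter), a modest loss. Against the piperazin-1-yl chain, the same chain gives a 2.1-fold lower number from compound 1 to compound 3 (0.33 log units; beyond the scatter), placing it between the other two. Nothing shown explains either step. Still open, from the compounds shown here alone, is how a simple amine or a carboxylic acid at the end of this chain would compare, and whether a longer chain carrying the imidazole would come closer to compound 2.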